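Heteroaryl swap at the dienone terminus: furan to thiophene

A few compounds are considered here, and "the series" means these few. Any claim that something is new, unique, unknown or untested is made for them only; others in the source may bear on it.

Measured so far:
compound 1 `COc1cc(OC)c2c(=O)c(OCCCOc3ccccc3/C=C/C(=O)/C=C/c3ccccn3)c(-c3cc(OC)c(OC)c(OC)c3)oc2c1` — in a functional assay on SMMC-7721 cells (Homo sapiens) for antiproliferative activity, read by MTT assay, with a stated time of 48 h (a lower number here means a stronger inhibitor, a higher number a weaker inhibitor), compound 1 gives 3180 nM
compound 2 `COc1cc(OC)c2c(=O)c(OCCCOc3ccccc3/C=C/C(=O)/C=C/c3cccc([N+](=O)[O-])c3)c(-c3cc(OC)c(OC)c(OC)c3)oc2c1` — compound 2 gives 9200 nM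
compound 3 `COc1cc(OC)c2c(=O)c(OCCCCOc3ccccc3/C=C/C(=O)/C=C/c3ccco3)c(-c3cc(OC)c(OC)c(OC)c3)oc2c1` — compound 3 gives 8480 nM

Compound 3 sits close to compound 2 in this assay, the gap between them within the scatter, and gives a higher number than compound 1, that gap lying beyond the scatter. The next compound, compound 4 `COc1cc(OC)c2c(=O)c(OCCCCOc3ccccc3/C=C/C(=O)/C=C/c3cccs3)c(-c3cc(OC)c(OC)c(OC)c3)oc2c1`, differs from compound 3 by thiophen-2-yl in place of furan-2-yl on a double-bonded chain carbon bound to a double-bonded chain carbon; the chain and the shared core are otherwise unchanged. For the measured compounds named here, only one measured step touches the same place on the chain, a 2.9-fold higher number from compound 1 to compound 2 (0.46 log units; beyond the scatter), and it exchanges a pyridinyl for a nitrophenyl, a different pair of groups; no measured step exchanges a furanyl for a thienyl. The two groups are counted alike in size and in donors and acceptors, so the exchange is expected to read as a small step, a 1.1-fold lower number from compound 3 to compound 4 (0.05 log units; within the scatter), not beyond the scatter. Compound 4 is therefore estimated at 7500 nM in this assay, with a range of 3500 nM to 16000 nM.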

Compound 4, half-maximal inhibitory concentration: 14900 nM
The estimate for compound 4 lay 2.0-fold (0.30 log units) below the measured number; the measured number falls inside the stated range.
By their numbers in this assay, from the lowest: compound 1; then compounds 3, 2 and 4 (each within the scatter of the next).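

In this assay, thiophen-2-yl in place of furan-2-yl on a double-bonded chain carbon bound to a double-bonded chain carbon gives a 1.8-fold higher number from compound 3 to compound 4 (0.24 log units; within the scatter) and so opens no resolved gap between these two rings. For the compounds shown here, the one earlier step at this place, a 2.9-fold higher number from compound 1 to compound 2 (0.46 log units; beyond the scatter), exchanged a different pair of groups and lay beyond the scatter, whereas this exchange keeps the heavy-atom count, ring size and hydrogen-bond counts and replaces only oxygen with sulfur. No supporting measurement bears on this result.

Compound 1 and compound 3 differ in both the chain and the terminal group, leaving the separate contribution of each unresolved. As far as these compounds go, how a piperidin-1-yl group or a carboxylic acid would read at this place, and whether thiophen-2-yl and furan-2-yl stay this close on the chain of compound 1, remains open.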